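This account rests on a few compounds, and the source may have more. Where it says the series, first, only, none or still open, it means among the compounds named here.

Compound 1 `O=c1c(-c2ccc(F)cc2)c[nH]c2ccnc(Nc3ccc(Oc4ccnc5cc(OCCO)ccc45)c(F)c3)c12` gives 4700 nM
Compound 2 `CC(O)COc1ccc2c(Oc3ccc(Nc4nccc5[nH]cc(-c6ccc(F)cc6)c(=O)c45)cc3F)ccnc2c1` gives 3100 nM

In a functional assay on MKN-45 cells (Homo sapiens) for antiproliferative activity, read by MTT assay, with a stated time of 72 h (a lower number here means a stronger inhibitor, a higher number a weaker inhibitor), compound 2 gives 3100 nM and sits level with compound 1 within the scatter. Compound 3 `COC(C)(C)COc1ccc2c(Oc3ccc(Nc4nccc5[nH]cc(-c6ccc(F)cc6)c(=O)c45)cc3F)ccnc2c1` differs from compound 2 by 1-methoxy-1-methylethyl in place of 1-hydroxyethyl on a saturated chain carbon bound to an oxygen on an aromatic ring on the same chain. Within the data shown here, the one measured step on this chain is a 1.5-fold lower number from compound 1 to compound 2 (0.18 log units; within the scatter) and it is small, but no measured compound carries 2-methoxy-2-methylpropoxy, so the evidence is thin. In this assay the expected change is a 1.1-fold lower number from compound 2 to compound 3 (0.04 log units; within the scatter) with nothing beyond the scatter foreseen. Compound 3 is estimated at 2800 nM with an expected range from 900 nM to 8500 nM on this thin evidence.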

Compound 3, half-maximal inhibitory concentration: 5500 nM
Beside the measured number, compound 3's estimate is 2.0-fold (0.29 log units) below it; low and high end bracket the measured number.
By their numbers in this assay, from the lowest: compounds 2, 1 and 3 (each within the scatter of the next).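

Entering 1-methoxy-1-methylethyl gives a 1.8-fold higher number from compound 2 to compound 3 (0.25 log units; within the scatter) and, in place of hydroxymethyl, a 1.2-fold higher number from compound 1 to compound 3 (0.07 log units; within the scatter) in this assay on the saturated chain carbon bound to an oxygen on an aromatic ring. The two earlier compounds both carried a hydrogen-bond donor in this group, and compound 3, with none and with more heavy atoms, still sits level with both within the scatter. No measurement shown here accounts for these numbers. On these data alone, whether an amine, a carboxylic acid or a longer chain at this place would move the number beyond the scatter stays open.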